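A few compounds are considered here, and "the series" means these few. Any claim that something is new, unique, unknown or untested is made for them only; others in the source may bear on it.

Measured compounds:
compound 1 `CCN(CC)CCCNC(=O)C(c1ccccc1)c1ccccc1` — 4400 nM
compound 2 `CN(CCCNC(=O)C(c1ccccc1)c1ccccc1)Cc1ccccc1` — 1200 nM

Two amides of a shared core have been measured in an assay on CHO cells for inhibition of sodium channel protein type 2 subunit alpha (Rattus norvegicus); a higher number here means a weaker inhibitor, a lower number a stronger inhibitor. Among the measured compounds shown here, compound 1 gives 4400 nM; compound 2 gives 1200 nM, the lower of the two numbers, and the single step, a 3.7-fold lower number from compound 1 to compound 2 (0.56 log units; beyond the scatter), lies beyond the scatter.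

Compound 3 `CC1CCC(C)N1CCCNC(=O)C(c1ccccc1)c1ccccc1` has not yet been measured in this assay. It differs from compound 2 in one place: 2,5-dimethylpyrrolidin-1-yl in place of benzyl(methyl)amino on a saturated chain carbon, three bonds along the chain from an amide-type nitrogen. For the measured compounds named here, the only step that bears on this change is the one from compound 1 to compound 2, which replaced a dialkylamine with an amine carrying a benzyl group and gave the modest drop already quoted. Compound 3 returns to a dialkylamine, here a ring, so the new group resembles that of compound 1 more than that of compound 2. The expected step, a 2.5-fold higher number from compound 2 to compound 3 (0.40 log units; beyond the scatter), is therefore toward a higher number, of a size near that step reversed, though with wide uncertainty. The estimate for compound 3 is 3000 nM, with a range from 1000 nM to 9000 nM.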

Compound 3, half-maximal inhibitory concentration: 4600 nM
For compound 3 the middle estimate is 1.5-fold (0.19 log units) below the measured one, within the range that was stated.
By their numbers in this assay, from the lowest: compound 2; then compounds 1 and 3 (each within the scatter of the next).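

In this assay, the 2,5-dimethylpyrrolidin-1-yl group in place of benzyl(methyl)amino gives a 3.8-fold higher number from compound 2 to compound 3 (0.58 log units; beyond the scatter) and does not keep the low number of compound 2. In place of diethylamino, the same ring gives a 1.0-fold higher number from compound 1 to compound 3 (0.02 log units; within the scatter) and so cannot be told apart from that open amine at this place on the chain; of the three compounds, only compound 2, whose group holds a six-membered aromatic ring of carbon only, stands apart, with the lowest number. Nothing measured here gives a reason for either step.

Open, from the compounds shown here alone, is whether phenethyl(methyl)amino or dibenzylamino would keep or extend the low number of compound 2. Also open, going by these compounds, is whether unsubstituted pyrrolidin-1-yl would read like compound 3, and how a longer chain would affect the benzyl(methyl)amino compound.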